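The compounds below may be only part of what the source reports. "The series", "measured", "known", "first", "only" and "open" are said of these compounds alone.

Compound 1 `O=C(/C=C/c1ccc2c(c1)B(O)OC2)c1ccc(OCc2ccccc2)cc1`: > 10 ug/mL
Compound 2 `O=C(/C=C/c1ccc2c(c1)B(O)OC2)c1ccc(Br)cc1`: > 10 ug/mL
Compound 3 `O=C(/C=C/c1ccc2c(c1)B(O)OC2)c1ccc(I)cc1`: not yet measured

In an ADME assay on L929 cells (Mus musculus) for cytotoxicity, read by resazurin assay, with a stated time of 72 h (on this read-out higher numbers stand for weaker inhibition and lower numbers for stronger inhibition), compound 2 gives > 10 ug/mL, which is a limit and not a number. Compound 1 gives > 10 ug/mL, also a limit. Both sit at the same limit: the limit of > 10 ug/mL in this assay, at which 2 of the 2 values shown sit. The change to compound 3 is iodo in place of bromo on an aromatic carbon. Going by the values given here, the only measured step, a step that the two limits leave unreadable from compound 1 to compound 2, bears on this but gives no size to carry over. No shift beyond the scatter is expected, and the estimated step is a step that the limit leaves unreadable from compound 2 to compound 3. A limit reading is again the likeliest outcome. The expected value for compound 3 is 15 ug/mL, with an estimated range of 8 ug/mL to 40 ug/mL.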

Compound 3, half-maximal inhibitory concentration: > 10 ug/mL
Compound 3: no number, only a limit; the forecaster's own chance of this, stated with the estimate: 80%; the middle value lies beyond the limit too.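

In this assay, going by these compounds alone, compound 1, compound 2 and compound 3 all give only a limit, and no step among them can be read: the limit of > 10 ug/mL in this assay, at which 3 of the 3 values shown sit. Where the cytotoxicity of each compound lies beyond that limit, and whether the three differ at all, stays open.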